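Adding a Hydroxy Where Every Value Is a Limit

This account rests on a few compounds, and the source may have more. Where it says the series, first, only, none or still open, it means among the compounds named here.

Of the compounds shown here, three sharing one core have been tested in a functional assay on BV-2 cells (Mus musculus) for inhibition, read by Griess assay, with a stated time of 24 h (on this read-out higher numbers stand for weaker inhibition and lower numbers for stronger inhibition), so far. Compound 1 (`Cc1c2c(cc(C(C)C)cc1=O)[C@@H](C)CC2`) gives > 30000 nM as a limit, not a number. Compound 2 (`Cc1c2c(cc(C(C)C)cc1=O)[C@@](C)(O)CC2`) gives > 30000 nM as a limit too. Compound 3 (`Cc1c2c(cc(C(C)C)cc1=O)[C@@H](C)C[C@@H]2O`) gives > 30000 nM as a limit as well. The set offers only (the limit of > 30000 nM in this assay, at which 3 of the 3 values shown sit) and no number to rank compound 3 against.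

Compound 4 (`CC(C)c1cc2c(c(CO)c(=O)c1)[C@@H](O)C[C@@H]2C`) differs from compound 3 in one place (hydroxy in place of hydrogen on a saturated chain carbon bound to an aromatic carbon), methyl to hydroxymethyl: hydroxy in place of hydrogen on a saturated chain carbon bound to an aromatic carbon. The closest measured changes, (a step that the two limits leave unreadable from compound 1 to compound 2) and (a step that the two limits leave unreadable from compound 1 to compound 3), also put hydroxy in place of hydrogen, but on a saturated ring carbon, and neither has a readable size. With no size to carry over, compound 4 is expected to stay at or close to the same limit in this assay testing. The estimated move is (a number no higher from compound 3 to compound 4 (the limit leaves the size open)) with no clear direction expected. For compound 4 the estimated value is 30000 nM with an expected span from 12000 nM to 60000 nM as its range.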

Compound 4, half-maximal inhibitory concentration: 20000 nM
The estimate for compound 4 lay 1.5-fold (0.18 log units) above the measured number; the range from low to high includes it.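

In this assay, methyl to hydroxymethyl on a saturated chain carbon bound to an aromatic carbon gives an at least 1.5-fold lower number from compound 3 to compound 4 (0.17 log units; that floor lies within the scatter). Going by these compounds alone, this is the only step in the set with a readable size, as the earlier steps that put hydroxy on a saturated ring carbon cannot be read, so this is the one place where adding a hydroxy comes with a number instead of a limit. Even so, the step is only a floor that stays within the usual scatter, and compound 4 stands alone with a number: the limit of > 30000 nM in this assay, at which 3 of the 4 values shown sit.

Compound 4 also carries the ring hydroxy of compound 3, which leaves open whether hydroxymethyl would give a number on the core of compound 1 without it. Also open, from the compounds shown here alone, is how an amine or a carboxylic acid at this place would read.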